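Compound 2 and a larger group on the same core

The source may hold more compounds than are shown below. What is called first, only, known or untested is meant among the compounds shown, and "the series" means these compounds.

compound 1 `COc1ccc(S(=O)(=O)Oc2ccccc2/C=C(\C#N)C(=O)Nc2nnc(-c3cccs3)s2)cc1`: 40%
compound 2 `N#C/C(=C\c1ccccc1OS(=O)(=O)c1ccc([N+](=O)[O-])cc1)C(=O)Nc1nnc(-c2cccs2)s1`: 33%
compound 3 `Cc1ccc(S(=O)(=O)Oc2cccc(/C=C(\C#N)C(=O)Nc3nnc(-c4ccccc4)s3)c2)cc1`: 52%

In an ADME assay on HEK-293T cells (Homo sapiens) for inhibition, read by CCK-8 assay, with a stated time of 48 h, tested at 20 uM (a higher number here means more inhibition of growth at the concentration tested, a lower number less inhibition of growth), compound 2 gives 33%. Among the compounds with values here, the one measured step between these compounds reads a number 7 percentage points lower from compound 1 to compound 2 (within the scatter), with nitro in place of methoxy on an aromatic carbon. Compound 3 gives a clearly higher number, 52%, but it differs from compound 2 in more than one place.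

Compound 4 `N#C/C(=C\c1ccccc1OS(=O)(=O)c1ccc([N+](=O)[O-])cc1)C(=O)Nc1nnc(Cc2cccc3ccccc23)s1` keeps everything in compound 2 except one group: (naphthalen-1-yl)methyl in place of thiophen-2-yl on an aromatic carbon. The change is (naphthalen-1-yl)methyl in place of thiophen-2-yl on an aromatic carbon of a five-membered aromatic ring with 2 nitrogen and 1 sulfur. Within the data shown here, the measured step concerns a different part of the molecule, and no measured step isolates a change at this place. It therefore gives no direct guide to size or direction. Among the measured compounds shown here, the only hint is that compound 3, which carries another group here, reaches 52%, so a slight upward lean is expected, though nothing firm beyond the scatter. The estimated change is a number 7 percentage points higher from compound 2 to compound 4 (within the scatter). For compound 4 the expected value in this assay is 40%, with an estimated range from 22% to 60%.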

Compound 4, percent growth inhibition at one concentration: 25%
Beside the measured number, compound 4's estimate is 15 percentage points above it, within the range that was stated.
By their numbers in this assay, from the lowest: compounds 4, 2 and 1 (each within the scatter of the next, the first and the last beyond it); then compound 3.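

Within the data shown here, with this step, the place on the aromatic carbon of the five-membered aromatic ring with 2 nitrogen and 1 sulfur has a measured change for the first time: in this assay, the result reads a number 8 percentage points lower from compound 2 to compound 4 (within the scatter). Thiophen-2-yl, with 5 heavy atoms and one five-membered aromatic ring, gives way to (naphthalen-1-yl)methyl, with 11 heavy atoms and 2 six-membered aromatic rings of carbon only, and the read-out still stays within the scatter, so this much larger carbon-only group does not measurably shift growth inhibition on the core of compound 2. Nothing in the data available here accounts for this outcome.

As far as these compounds go, it remains open whether a polar group at this place, such as an amine or a carboxylic acid, or a smaller group such as benzyl, would move the number beyond the scatter from compound 2. Also open, from the compounds shown here alone, is whether (naphthalen-1-yl)methyl would give the same kind of step on the core of compound 1, which carries methoxy in place of nitro.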